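The source may report more compounds than this note shows. Statements on the series, on what has been measured and on what is new or still open speak of the compounds shown alone.

The measured compounds and their values:

compound 1, `COC(=O)[C@H](CCSC)NC(=O)c1ccc(CNCc2c[nH]cn2)cc1-c1ccccc1C`, which in a functional assay on NIH3T3 cells (Mus musculus) (on this read-out higher numbers stand for an effect only at larger amounts of compound and lower numbers for an effect already at smaller amounts), gives 25 uM;
compound 2, `COC(=O)[C@H](CCSC)NC(=O)c1ccc(NCc2cncn2Cc2ccc(C)cc2)cc1-c1ccccc1`, for which this assay reports no number but a limit, > 10 uM.

Compound 2 therefore stands at the edge of what this assay resolves, as recorded in the limit of > 10 uM in this assay, at which 1 of the 2 values shown sits. For the measured compounds named here, compound 1 sits at a measurable concentration, but the two structures differ in more than one place, and no step between them is computed; their two values show only that one is a number and the other a limit.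

Compound 3, `COC(=O)[C@H](CCSC)NC(=O)c1ccc(NCc2cncn2Cc2cccc(C#N)c2)cc1-c1ccccc1`, is not yet measured. It differs from compound 2 by 3-cyanophenyl in place of 4-methylphenyl on a saturated chain carbon bound to an aromatic nitrogen. Going by the values given here, nothing among the measured pair speaks to this exchange, so the step that the limit leaves unreadable from compound 2 to compound 3 is expected to be small, within the usual scatter, with no direction favoured. Compound 3 is estimated in this assay at 15 uM, within a range from 4 uM to 60 uM, and it is expected that this assay may again return only a limit rather than a number.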

Compound 3, concentration for half-maximal effect: > 10 uM
Compound 3: only a limit was reported; the forecaster's own chance of this, stated with the estimate: 60%; the middle value does not contradict the limit.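

Compound 2 and compound 3 each return only a limit in this assay, so no step can be read from the exchange of 4-methylphenyl for 3-cyanophenyl: the limit of > 10 uM in this assay, at which 2 of the 3 values shown sit.

The compounds shown leave open how far these two groups differ in this assay, and where compound 2 and compound 3 stand relative to compound 1.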